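The compounds below may be only part of what the source reports. "The series", "measured", "known", "first", "only" and "open" are said of these compounds alone.

The series is built on a shared core and differs in the ether group carried on one aromatic ring. Compound 1 `CCS(=O)(=O)Nc1ccc(Oc2ccc(C(F)(F)F)cc2)c(-c2cn(C)c(=O)c3[nH]ccc23)c1` carries a trifluoromethyl-substituted phenoxy group, and in an ADME assay on microsomes from liver (Homo sapiens) for metabolic stability, read by HPLC, using NADPH, with stated times of 5 min and 60 min, tested at 10 uM (a lower number here means slower removal, a higher number faster removal of the compound), compound 1 gives 128 mL/min/kg. Compound 2 `Cn1cc(-c2cc(NS(C)(=O)=O)ccc2Oc2ccc(F)cc2Cl)c2cc[nH]c2c1=O` carries a 2-chloro-4-fluorophenoxy group instead, and in this assay compound 2 gives 233 mL/min/kg. Of the two numbers recorded, compound 2 has the higher one, but the gap to compound 1 lies within the usual scatter of this kind of measurement, so the two compounds cannot be set apart on clearance.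

Compound 3 `Cn1cc(-c2cc(NS(C)(=O)=O)ccc2OC2CCC(F)(F)CC2)c2cc[nH]c2c1=O` has not yet been measured. It differs from compound 2 in one place: 4,4-difluorocyclohexyl in place of 2-chloro-4-fluorophenyl on an oxygen on an aromatic ring. Going by the values given here, no step between measured compounds of the same kind is available, so the direction of the change rests on no precedent. Given that compound 1 and compound 2 sit within the scatter of each other despite their different aryl ethers, the expectation for compound 3 is a value of 160 mL/min/kg, between 70 mL/min/kg and 330 mL/min/kg. That estimate means a step from compound 2 to compound 3 of a 1.5-fold lower number from compound 2 to compound 3 (0.16 log units; within the scatter), which is not expected to exceed the scatter.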

Compound 3, clearance: < 38.4 mL/min/kg
Compound 3: only a limit was reported; the forecaster's own chance of this, stated with the estimate: 5%; middle value at least 4.1-fold (0.61 log units) from the limit.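

In this assay compound 3 is reported only as a limit, < 38.4 mL/min/kg, and not as a number. Going by these compounds alone, on an oxygen on an aromatic ring, 4,4-difluorocyclohexyl in place of 2-chloro-4-fluorophenyl gives an at least 6.0-fold lower number from compound 2 to compound 3 (0.78 log units; beyond the scatter), the first step between compounds that differ in one place, and it shows that this position alone can move clearance beyond the scatter. The change replaces one six-membered aromatic ring of carbon with a six-membered non-aromatic ring of carbon, and it also exchanges chlorine and fluorine for two fluorines on a group of the same heavy-atom count, so the step shows the effect of the whole exchange and not of any one part of it; the limit itself sets how far the step can be read: the limit of < 38.4 mL/min/kg in this assay, at which 1 of the 3 values shown sits.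

The compounds shown do not tell whether the non-aromatic ring or its two fluorines carry the step, which a plain cyclohexyl on the same oxygen would begin to separate. They also leave open how a ring holding a nitrogen, such as a piperidine, would read at this position, and how far under its limit compound 3 truly lies.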